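Aryl swap on the carbonyl carbon: compound 2 to compound 3

The source may report more compounds than this note shows. Statements on the series, on what has been measured and on what is new or still open speak of the compounds shown alone.

Measured so far:
compound 1 `COc1cc(-c2cc(/C=C/C(=O)c3ccc(N)cc3)[nH]n2)cc(OC)c1OC` — 106%
compound 2 `COc1cc(-c2cc(/C=C/C(=O)c3ccc(Cl)c(Cl)c3)[nH]n2)cc(OC)c1OC` — 100%

In a functional assay on NCI/ADR-RES cells (Homo sapiens) for cytotoxicity, read by sulforhodamine B assay, with a stated time of 48 h, tested at 0.01 uM (a higher number here means a weaker effect of the compound at the concentration tested, a lower number a stronger effect), compound 1 gives 106% and compound 2 gives 100%. Compound 2 has the smaller of the two numbers shown; the nearest is compound 1, and the step of a number 6 percentage points lower from compound 1 to compound 2 (within the scatter) lies within the scatter, so the two values cannot be told apart. Both sit near the level of untreated cells at this concentration.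

Compound 3 `COc1ccc(C(=O)/C=C/c2cc(-c3cc(OC)c(OC)c(OC)c3)n[nH]2)cc1OC` is not yet measured. Its change from compound 2 is 3,4-dimethoxyphenyl in place of 3,4-dichlorophenyl on a carbonyl carbon.

Among the measured compounds shown here, only one measured step bears on this change: the step from compound 1 to compound 2 also swapped the aryl group on the carbonyl carbon, and it gave a number 6 percentage points lower from compound 1 to compound 2 (within the scatter), within the scatter. With both aryl variants so far leaving the read-out unchanged, no step beyond the scatter is expected in this assay for this third aryl variant either.

Compound 3 is therefore expected to give about 100%, in the range 86% to 114%. This estimate means a step of no change at the digits printed from compound 2 to compound 3 (within the scatter).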

Compound 3, a percentage reported as activity, at one concentration (the size of the read-out at that concentration, not a potency): 99%
Beside the measured number, compound 3's estimate is 1 percentage points above it, and the stated range covers the measured number.
By their numbers in this assay, from the lowest: compounds 3, 2 and 1 (each within the scatter of the next).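

In this assay, a number 1 percentage points lower from compound 2 to compound 3 (within the scatter), so 3,4-dimethoxyphenyl and 3,4-dichlorophenyl on a carbonyl carbon cannot be told apart, although the two groups differ in their atoms, with oxygen in one and chlorine in the other, and in heavy-atom count, and only 3,4-dimethoxyphenyl carries hydrogen-bond acceptors. The comparison with the amine-bearing aryl group gives the same reading: a number 7 percentage points lower from compound 1 to compound 3 (within the scatter), which means that all three aryl variants at this place now lie within the scatter of one another, and the earlier pair alone could not show this for a group with oxygen substituents. No measured data are available to explain this lack of separation.

These values come from a single low concentration and are not potencies, so they leave open whether the three compounds would separate at a concentration where the read-out moves away from the level of untreated cells. Also open, going by these compounds, is whether an aryl group carrying a carboxylic acid or a trifluoromethyl group, or a longer chain on the carbonyl carbon in place of an aryl group, would give a step beyond the scatter.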